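Swapping methyl for nitro on a weakly active compound

The source may hold more compounds than are shown below. What is called first, only, known or untested is meant among the compounds shown, and "the series" means these compounds.

Values in a functional assay on HT-29 cells (Homo sapiens) for antiproliferative activity, read by sulforhodamine B assay, with a stated time of 48 h (on this read-out higher numbers stand for weaker inhibition and lower numbers for stronger inhibition), are as follows
Compound 1 `CCCN1CCN(c2ccc(S(=O)(=O)Oc3ccccc3CC)cc2)C1=O` gives > 100000 nM (a limit of the assay)
Compound 2 `CCCN1CCN(c2ccc(S(=O)(=O)Oc3cc(Cl)c(Cl)cc3Cl)cc2)C1=O` gives 19000 nM
Compound 3 `CCCN1CCN(c2ccc(S(=O)(=O)Oc3cccc(C)c3)cc2)C1=O` gives 65000 nM

Of the two true numbers, compound 3 has the higher, with a 3.4-fold higher number from compound 2 to compound 3 (0.53 log units; beyond the scatter) as the gap. Compound 4 `CCCN1CCN(c2ccc(S(=O)(=O)Oc3cccc([N+](=O)[O-])c3)cc2)C1=O` has nitro in place of methyl on an aromatic carbon and so turns 3-methylphenyl into 3-nitrophenyl. Within the data shown here, no measured step makes this exact swap. The closest guides also change the phenyl group on the oxygen: an at least 5.2-fold lower number from compound 1 to compound 2 (0.72 log units; beyond the scatter) and an at least 1.5-fold lower number from compound 1 to compound 3 (0.18 log units; that floor lies within the scatter) are both small or modest, like the gap above. In this assay the expected step is a 1.6-fold lower number from compound 3 to compound 4 (0.21 log units; within the scatter) and may stay within the scatter. For compound 4 the estimated value is 40000 nM (expected range 15000 nM to 100000 nM).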

Compound 4, half-maximal inhibitory concentration: > 100000 nM
Compound 4: only a limit was reported; the forecaster's own chance of this, stated with the estimate: 15%; middle value at least 2.5-fold (0.39 log units) from the limit.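

In this assay, nitro in place of methyl on this aromatic carbon brought no gain in activity, with an at least 1.5-fold higher number from compound 3 to compound 4 (0.18 log units; that floor lies within the scatter). The 2,4,5-trichlorophenyl group of compound 2 keeps a clear lead over 3-nitrophenyl, with an at least 5.2-fold higher number from compound 2 to compound 4 (0.72 log units; beyond the scatter). The step between compound 1 and compound 4 cannot be read, and compound 4 is reported only as a limit: the limit of > 100000 nM in this assay, at which 2 of the 4 values shown sit. As far as these compounds go, how far compound 4 lies past that limit remains unknown, so it is unclear whether nitro is truly weaker than methyl here. From the compounds shown here alone, whether an amine or a carboxylic acid in this place would improve activity also remains open.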